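Swapping 3-methoxyphenyl for 1H-pyrazol-5-yl on a carbonyl carbon

A few compounds are considered here, and "the series" means these few. Any claim that something is new, unique, unknown or untested is made for them only; others in the source may bear on it.

Three compounds have been measured so far in a toxicity assay on THP-1 cells (Homo sapiens) for inhibition; a higher number here means that more compound is tolerated, a lower number that less compound is tolerated:
- Compound 1 `COc1ccc(-c2cnc(NC(=O)c3ncc[nH]3)n2C)cc1` gives > 100000 nM as a limit
- Compound 2 `COc1ccc(-c2cnc(NC(=O)c3cccc(O)c3)n2C)cc1` gives > 100000 nM as a limit
- Compound 3 `COc1ccc(-c2cnc(NC(=O)c3cccc(OC)c3)n2C)cc1` gives > 100000 nM as a limit

Compound 3 stands at > 100000 nM as a limit, not a number. For the measured compounds named here, the whole picture so far is the limit of > 100000 nM in this assay, at which 3 of the 3 values shown sit, so no compound can be ranked against another.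

Compound 4 `COc1ccc(-c2cnc(NC(=O)c3ccn[nH]3)n2C)cc1` carries 1H-pyrazol-5-yl in place of 3-methoxyphenyl on the carbonyl carbon (1H-pyrazol-5-yl in place of 3-methoxyphenyl on a carbonyl carbon).

Two measured changes sit at this same carbonyl carbon: a step that the two limits leave unreadable from compound 1 to compound 3 and a step that the two limits leave unreadable from compound 1 to compound 2. The methyl change on the oxygen is also a step that the two limits leave unreadable from compound 2 to compound 3. None of them has a size to carry over.

Compound 1, with 1H-imidazol-2-yl on that carbonyl carbon, gives > 100000 nM as a limit.

The expected step is a number no higher from compound 3 to compound 4 (the limit leaves the size open) in this assay, with no direction foreseen. For compound 4 the estimated value is 100000 nM within an expected range of 50000 nM to 200000 nM in this assay, most likely reported again as a limit.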

Compound 4, half-maximal cytotoxic concentration: > 100000 nM
Compound 4: no number, only a limit; the forecaster's own chance of this, stated with the estimate: 90%; the middle value sits exactly at the limit.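

In this assay no step can be read among compound 1, compound 2, compound 3 and compound 4, since each gives only a limit and not a number: the limit of > 100000 nM in this assay, at which 4 of the 4 values shown sit.

The compounds shown leave open how much of any of them the cells tolerate, and whether changing the group on the carbonyl carbon alters that tolerance at all.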